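Swapping the Aryl Group on the Amine Nitrogen

The source may report more compounds than this note shows. Statements on the series, on what has been measured and on what is new or still open speak of the compounds shown alone.

Of the compounds shown here, three sharing one core have been measured in a functional assay on NCI-H226 cells (Homo sapiens) for inhibition, read by MTT assay, with a stated time of 48 h, tested at 10 uM; on this read-out lower numbers stand for less inhibition and higher numbers for more inhibition at the one concentration tested (going by the name of the read-out). Compound 1 `COc1cc(NC(=O)Nc2cc(Nc3ccc(C(C)(C)C)cc3)ncn2)cc(OC)c1` gives 47.7%, and compound 3 `COc1cc(NC(=O)Nc2cc(Nc3ccc(C)c(C)c3)ncn2)cc(OC)c1` gives 45.3%. Within the data shown here, the only single change measured so far, a number 2.4 percentage points lower from compound 1 to compound 3 (within the scatter), swaps the group on a nitrogen on an aromatic ring, the same place varied below. Compound 2 `COc1ccc(F)cc1Nc1cc(NC(=O)Nc2c(Cl)cccc2Cl)ncn1` gives 31.3%, the lowest of the three numbers, beyond the scatter from both others.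

Compound 4 `Cc1cc(F)cc(Nc2cc(NC(=O)Nc3c(Cl)cccc3Cl)ncn2)c1` has not yet been measured. It differs from compound 2 by 3-fluoro-5-methylphenyl in place of 5-fluoro-2-methoxyphenyl on a nitrogen on an aromatic ring. Among the measured compounds shown here, since the one measured step at this place stayed within the scatter, no step beyond the scatter is expected; the change from compound 2 to compound 4 is estimated at a number 1.7 percentage points higher from compound 2 to compound 4 (within the scatter). Compound 4 is therefore expected to give about 33%, somewhere between 16% and 50%.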

Compound 4, a percentage reported as inhibition, at one concentration (the size of the read-out at that concentration, not a potency): 78.1%
Compound 4: the middle estimate sits 45.1 percentage points below what was measured, outside the stated range (above it).
By their numbers in this assay, from the lowest: compound 2; then compounds 3 and 1 (each within the scatter of the next); then compound 4.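

At this position, the choice of aryl group on the nitrogen can matter greatly: in this assay, 3-fluoro-5-methylphenyl in place of 5-fluoro-2-methoxyphenyl gives a number 46.8 percentage points higher from compound 2 to compound 4 (beyond the scatter), whereas the earlier step here stayed within the scatter. The change replaces methoxy with methyl and also alters the substitution pattern, so this single step cannot show which of the two counts. No measurement shown here accounts for the size of this step.

Going by these compounds, whether 3-fluoro-5-methylphenyl would give a similar result on the core of compound 1 remains open. So does the outcome with a phenyl group carrying an amine or a carboxylic acid.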